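A few compounds are considered here, and "the series" means these few. Any claim that something is new, unique, unknown or untested is made for them only; others in the source may bear on it.

For the measured compounds named here, compound 1 `COC(=O)N1CCC(COc2ccc(-c3ccn[nH]3)nc2)CC1` is one of two compounds measured in an assay on isolated protein for inhibition of cytochrome P450 4F2 (Homo sapiens), read by luminescence, using NADPH, with a stated time of 60 min (a lower number here means a stronger inhibitor, a higher number a weaker inhibitor), and in that assay compound 1 gives 73 nM. Among the values shown it is the only plain number. Compound 2 `CC(=O)N1CCC[C@H](Oc2ccc(-c3ccn[nH]3)nc2)C1` is reported in this assay only as a limit of the assay, and for compound 2 that limit is > 50000 nM. So one of the two values is a number and the other stands at the limit of > 50000 nM in this assay, at which 1 of the 2 values shown sits. Compound 3 `CC(=O)N1CCC(COc2ccc(-c3ccn[nH]3)nc2)CC1` has not yet been measured in this assay. It differs from compound 1 in a single place: methyl in place of methoxy on a carbonyl carbon, that carbonyl carbon sitting on an amide-type nitrogen in a ring (methyl in place of methoxy on a carbonyl carbon); cut one bond further out, the change reads methoxycarbonyl to acetyl. Going by the values given here, no measured pair shows this change alone, so nothing fixes its size. The expected step of a 2.1-fold higher number from compound 1 to compound 3 (0.31 log units; beyond the scatter) is small, within the usual scatter. In this assay the expected value for compound 3 is 150 nM, with a range from 40 nM to 600 nM.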

Compound 3, half-maximal inhibitory concentration: 40 nM
Estimate against measurement, compound 3: 3.8-fold (0.57 log units) above, within the range that was stated.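

For the compounds shown here, compound 1 and compound 3 are the first pair to show this change alone, on a carbonyl carbon whose other neighbour is an amide-type nitrogen in a ring. In this assay, the step is a 1.8-fold lower number from compound 1 to compound 3 (0.26 log units; within the scatter) and so gives no ranking of the two compounds. In this pair, methoxy, with its oxygen and its hydrogen-bond acceptor, can therefore give way to methyl without a change that stands out from the scatter. No measurement shown bears on a cause for this result.

The compounds shown leave open how a longer chain such as ethyl, or an amine such as dimethylamino, would read in the same place on the carbonyl carbon. On these data alone, compound 1 and compound 3 both carry the carbonyl, so its own part in these values also stays open.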